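This account rests on a few compounds, and the source may have more. Where it says the series, first, only, none or still open, it means among the compounds named here.

Series notes. Compound 1 `CNc1nc(N)nc2c1ncn2/C=C1/CC1(CO)CO`, compound 2 `Nc1nc(NCc2ccccc2)c2ncn(/C=C3/CC3(CO)CO)c2n1` and compound 3 `CCCCCCCCSc1nc(N)nc2c1ncn2/C=C1/CC1(CO)CO` share one core and differ at a single aromatic carbon. In an ADME assay on Akata cells (Homo sapiens) for cytotoxicity, with a stated time of 7 days (on this read-out lower numbers stand for higher toxicity in this test and higher numbers for lower toxicity in this test), compound 2 gives > 24000 nM, which is a limit of the assay and not a number. Compound 1 gives > 24000 nM, likewise a limit. Compound 3 gives > 20000 nM, also a limit. Compound 2 thus sits at the limit of > 24000 nM in this assay, at which 2 of the 3 values shown sit, together with compound 1, while compound 3 sits at the limit of > 20000 nM in this assay, at which 1 of the 3 values shown sits; no ranking among the three can be read. The steps a step that the two limits leave unreadable from compound 1 to compound 2, a step that the two limits leave unreadable from compound 1 to compound 3 and a step that the two limits leave unreadable from compound 2 to compound 3 are all of unknown size for this reason.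

Compound 4 `CC(C)Sc1nc(N)nc2c1ncn2/C=C1/CC1(CO)CO` is not yet measured and differs from compound 2 as follows: isopropylsulfanyl in place of benzylamino on an aromatic carbon. The nearest measured change, from compound 2 to compound 3, also swapped the benzylamino for a sulfanyl chain and gave no readable size, both ends being limits. The expected step is therefore a step that the limit leaves unreadable from compound 2 to compound 4, with no movement beyond the scatter and a further limit the most likely outcome. Compound 4 is estimated at 30000 nM, within a range from 15000 nM to 60000 nM.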

Compound 4, half-maximal cytotoxic concentration: > 20000 nM
Compound 4 was reported as a limit; the forecaster's own chance of this, stated with the estimate: 80%; the middle value lies beyond the limit too.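

No new step can be read: compound 4, like compound 1, compound 2 and compound 3, stands only as a limit in this assay, so all its steps remain unreadable. The compounds shown leave open whether the substituents on the aromatic carbon differ at all in this test.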